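Inverting both stereocentres of compound 3

A few compounds are considered here, and "the series" means these few. Any claim that something is new, unique, unknown or untested is made for them only; others in the source may bear on it.

In a functional assay on MDA-MB-231 cells (Homo sapiens) for inhibition, read by MTT assay, with a stated time of 72 h (a lower number here means a stronger inhibitor, a higher number a weaker inhibitor), compound 1 (`CC1=NN(c2ccccc2)C(=O)[C@]12C(=O)C=CC[C@H]2c1ccc(C)cc1`) gives 5720 nM and compound 2 (`COc1ccccc1[C@@H]1CC=CC(=O)[C@]12C(=O)N(c1ccccc1)N=C2C`) gives 5140 nM while compound 3 (`CC1=NN(c2ccc(C)cc2)C(=O)[C@]12C(=O)C=CC[C@H]2c1ccc(C)cc1`) gives 8280 nM in the same band, all three within the scatter of one another. The move to compound 4 (`CC1=NN(c2ccc(C)cc2)C(=O)[C@@]12C(=O)C=CC[C@@H]2c1ccc(C)cc1`), still unmeasured, is one of configuration alone: the two compounds have the same atoms and bonds and differ only in configuration as drawn: 2 of 2 stereo elements differ (all stereocentres are inverted: mirror images); a stereocentre at a saturated ring carbon is drawn S in compound 3 and R in compound 4; a stereocentre at a saturated ring carbon is drawn S in compound 3 and R in compound 4 and nothing else changes. Among the compounds with values here, neither measured step bears directly on this: a 1.1-fold lower number from compound 1 to compound 2 (0.05 log units; within the scatter) and a 1.4-fold higher number from compound 1 to compound 3 (0.16 log units; within the scatter) are substituent changes, and no mirror-image pair has been measured. Without such a guide, the expected outcome is a 1.1-fold lower number from compound 3 to compound 4 (0.04 log units; within the scatter) with no shift beyond the scatter anticipated, though uncertainty remains wide. Compound 4 is estimated at 7500 nM with an expected range of 3500 nM to 16000 nM as a working figure.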

Compound 4, half-maximal inhibitory concentration: 8120 nM
The estimate for compound 4 lay 1.1-fold (0.03 log units) below the measured number; the range from low to high includes it.
By their numbers in this assay, from the lowest: compounds 2, 1, 4 and 3 (each within the scatter of the next).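

In this assay, within the data shown here, inverting both stereocentres gives a 1.0-fold lower number from compound 3 to compound 4 (0.01 log units; within the scatter), the first mirror-image pair and a step no larger than the substituent changes seen so far. For this pair, the configuration as drawn produces no shift beyond the scatter, and the comparison isolates that one variable: the fact that compounds 3 and 4 differ only in the configuration as drawn.

Still open, as far as these compounds go, is whether inverting only one stereocentre, giving a compound that is not a mirror image of compound 3, would read the same. From the compounds shown here alone, it is also open whether an amine or a carboxylic acid in place of the 4-methylphenyl group would move the number beyond the scatter.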